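The source may hold more compounds than are shown below. What is called first, only, known or untested is meant among the compounds shown, and "the series" means these compounds.

Measured in a functional assay on HL-60 cells (Homo sapiens) for antiproliferative activity, read by XTT assay, with a stated time of 72 h; on this read-out higher numbers stand for weaker inhibition and lower numbers for stronger inhibition:
- compound 1 `C=C(C)CCC[C@]1(C)C2=CCC[C@](C)(CC(=O)c3ccoc3)[C@H]2CC[C@H]1C`: > 100000 nM
- compound 2 `C=C(C)CCC[C@]1(C)C2=CCC[C@](C)(C[C@@H](O)C3=CC(=O)OC3O)[C@H]2CC[C@H]1C`: 3200 nM
- compound 3 `C=C(C)CCC[C@]1(C)C2=CCC[C@](C)(C[C@H](O)C3=CC(=O)OC3O)[C@H]2CC[C@H]1C`: 3000 nM

The entry for compound 1 is a limit of the assay, not a number. Going by the values given here, compound 3 and compound 2 hold the only true numbers in the set, and these cannot be told apart: a 1.1-fold lower number from compound 2 to compound 3 (0.03 log units; within the scatter). The single stereocentre that separates them therefore shows no effect in this assay.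

The next structure is compound 4 `C=C(C)CCC[C@]1(C)C2=CCC[C@](C)(C[C@@H](O)c3ccoc3)[C@H]2CC[C@H]1C`. The change is a group of 7 heavy atoms (5 carbon, 2 oxygen; one five-membered aromatic ring with 1 hetero atom) in place of a group of 9 heavy atoms (5 carbon, 4 oxygen; one five-membered non-aromatic ring with 1 hetero atom), on a saturated chain carbon bound to a saturated ring carbon. The closest evidence comes from compound 1, which also carries a five-membered aromatic ring. Two measured steps start there: an at least 31-fold lower number from compound 1 to compound 2 (1.49 log units; beyond the scatter) and an at least 33-fold lower number from compound 1 to compound 3 (1.52 log units; beyond the scatter). Both are large, and both are lower bounds set by the limit. Compound 4 reverses that ring exchange, so a large move to a higher number, meaning weaker inhibition, is expected. However, no measured compound combines this aromatic ring with a hydroxy group, so the step could be smaller.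

The expected step is a 17-fold higher number from compound 3 to compound 4 (1.22 log units; beyond the scatter).

For compound 4 the estimated value is 50000 nM, with an expected range from 15000 nM to 100000 nM.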

Compound 4, half-maximal inhibitory concentration: 31200 nM
For compound 4 the middle estimate is 1.6-fold (0.20 log units) above the measured one, and the stated range covers the measured number.
By their numbers in this assay, from the lowest: compounds 3 and 2 (each within the scatter of the next); then compound 4. At a limit, above all of these: compound 1.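

In this assay, the comparison now holds the hydroxy group in place and isolates the ring exchange: (furan-3-yl)(hydroxy)methyl replaces the five-membered non-aromatic ring group. Both routes give weaker inhibition: a 10-fold higher number from compound 3 to compound 4 (1.02 log units; beyond the scatter) and a 9.8-fold higher number from compound 2 to compound 4 (0.99 log units; beyond the scatter). The change from (furan-3-yl)carbonyl to (furan-3-yl)(hydroxy)methyl also matters on its own, with the furan ring kept: an at least 3.2-fold lower number from compound 1 to compound 4 (0.50 log units; beyond the scatter). That step gives only a minimum size, since compound 1 stands at a limit of the assay: the limit of > 100000 nM in this assay, at which 1 of the 4 values shown sits.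

The compounds shown leave open whether an amine in place of the hydroxy group on this carbon would keep or lose activity. They also leave open whether the configuration of the hydroxy-bearing carbon matters once the furan ring is present.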